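Ring Substituents and Cytotoxicity in A549 Cells

The source may hold more compounds than are shown below. What is called first, only, known or untested is meant among the compounds shown, and "the series" means these compounds.

Measured compounds:
compound 1, `C[S+]([O-])/C=C/c1cc(=O)c2ccccc2o1`: 1900 nM
compound 2, `C[S+]([O-])/C=C/c1cc(=O)c2cc(Cl)ccc2o1`: 1700 nM
compound 3, `COc1cccc2c(=O)cc(/C=C/[S+](C)[O-])oc12`: 2200 nM

In a functional assay on A549 cells (Homo sapiens) for cytotoxicity, with a stated time of 48 h (on this read-out higher numbers stand for weaker inhibition and lower numbers for stronger inhibition), compound 1 gives 1900 nM, the second highest of the three numbers shown; compound 2 lies nearest and compound 3 furthest, and both gaps fall within the scatter. Two single-point steps lead away from compound 1. The step of a 1.1-fold lower number from compound 1 to compound 2 (0.05 log units; within the scatter) brings chloro in place of hydrogen on an aromatic carbon, and the step of a 1.2-fold higher number from compound 1 to compound 3 (0.06 log units; within the scatter) brings methoxy in place of hydrogen on an aromatic carbon. Neither moves the number beyond the scatter.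

Compound 4, `CC(C)Oc1ccc2oc(/C=C/[S+](C)[O-])cc(=O)c2c1`, differs from compound 1 by isopropoxy in place of hydrogen on an aromatic carbon. Both measured steps bear on this change, since each also placed a small group on an aromatic carbon of the shared core and left the read-out essentially unchanged. The author therefore expects no step beyond the scatter in this assay. Compound 4 is estimated to give 2000 nM, with a range from 1000 nM to 4000 nM. The step this estimate implies is expected to be a 1.1-fold higher number from compound 1 to compound 4 (0.02 log units; within the scatter).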

Compound 4, half-maximal inhibitory concentration: 1500 nM
Compound 4: middle estimate off by 1.3-fold (0.12 log units), on the high side; the range from low to high includes it.
By their numbers in this assay, from the lowest: compounds 4, 2, 1 and 3 (each within the scatter of the next).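

In this assay, the step of a 1.3-fold lower number from compound 1 to compound 4 (0.10 log units; within the scatter) shows that this aromatic carbon of the shared core can carry isopropoxy, a group of 4 heavy atoms with no ring, without the read-out leaving the scatter. Exchanging chloro for isopropoxy on that same carbon gives a 1.1-fold lower number from compound 2 to compound 4 (0.05 log units; within the scatter), so the two groups cannot be told apart at this position in this read-out. No evidence is available that bears on this result.

The compounds shown leave open whether this carbon would tolerate an amine, a carboxylic acid or a longer alkoxy chain in the same way. Every step shown stays within the scatter, and whether any substituent on this ring can move the number beyond it remains an open question.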